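Fluoro for Methoxy on a Second Core

This account rests on a few compounds, and the source may have more. Where it says the series, first, only, none or still open, it means among the compounds named here.

Of the compounds shown here, three have been measured in a functional assay on HepG2 cells (Homo sapiens) for antiproliferative activity, read by sulforhodamine B assay, with a stated time of 48 h; a higher number here means a weaker inhibitor, a lower number a stronger inhibitor. Compound 1 `COc1ccc(C2C=C(c3cc(OC)c(OC)c(OC)c3)NC(=S)N2)cc1` gives 90 nM in this assay. Compound 3 `COc1cc(C2=CC(c3ccc(F)cc3)NC(=S)N2)cc(OC)c1OC` carries the change fluoro in place of methoxy on an aromatic carbon relative to compound 1, and in this assay compound 3 gives 61.9 nM; the step is a 1.5-fold lower number from compound 1 to compound 3 (0.16 log units; within the scatter). Compound 2 `COc1ccc(C2=NN(c3ccccc3)C(c3ccc(OC)cc3)C2O)cc1` rests on a different core, and the difference between the two cores is not broken down here. In this assay compound 2 gives 10.2 nM, the lowest number among the three measured compounds, with both neighbours beyond the scatter.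

Compound 4 `COc1ccc(C2=NN(c3ccccc3)C(c3ccc(F)cc3)C2O)cc1` has not yet been measured. It differs from compound 2 by fluoro in place of methoxy on an aromatic carbon, which is the same change as that from compound 1 to compound 3, made at a place described in the same words. Compound 4 is expected to give 8.5 nM in this assay, with a range from 4 nM to 18 nM. That expectation means a step of a 1.2-fold lower number from compound 2 to compound 4 (0.08 log units; within the scatter), and it rests on the earlier step, because the same change gave a 1.5-fold lower number from compound 1 to compound 3 (0.16 log units; within the scatter), a step within the scatter.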

Compound 4, half-maximal inhibitory concentration: 13 nM
Compound 4: the middle estimate sits 1.5-fold (0.18 log units) below what was measured; the measured number falls inside the stated range.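

In this assay, replacing 4-methoxyphenyl with 4-fluorophenyl on the core of compound 2 gives a 1.3-fold higher number from compound 2 to compound 4 (0.11 log units; within the scatter). Set beside the earlier step on the core of compound 1, the change does not separate the two cores: the same change on two cores in this assay, a 1.5-fold lower number (0.16 log units; within the scatter) from compound 1 to compound 3 and a 1.3-fold higher number (0.11 log units; within the scatter) from compound 2 to compound 4, 1.9-fold (0.27 log units) apart, within the scatter of two such steps. Among these compounds, on these two pairs, then, the change carries from one core to the other with neither step beyond the scatter, but this shows only that the swap left no readable mark on either core; it does not establish a direction for the change or show that it would hold on any further core.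

The compounds shown leave open whether a group other than fluoro, such as an amine or a carboxylic acid, would also stay within the scatter when placed on that aromatic carbon of either core. They also leave open how fluoro in place of methoxy would read at another position, or on a third core.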